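Aryl substitution pattern and dipeptidyl peptidase 9 inhibition

The source may hold more compounds than are shown below. What is called first, only, known or untested is meant among the compounds shown, and "the series" means these compounds.

compound 1, `CC#CCn1c(N2CCC[C@@H](N)C2)nc2c1c(=O)n(Cc1c(Br)cccc1C(=O)O)c(=O)n2C`: > 100000 nM
compound 2, `CC#CCn1c(N2CCC[C@@H](N)C2)nc2c1c(=O)n(Cc1c(Cl)cccc1C(=O)O)c(=O)n2C`: > 100000 nM

In an ADME assay on isolated protein for inhibition of Dipeptidyl peptidase 9 (Homo sapiens), with stated times of 15 min, 60 s and 20 min (on this read-out higher numbers stand for weaker inhibition and lower numbers for stronger inhibition), compound 1 gives > 100000 nM, which is a limit of the assay and not a number. In this assay compound 2 gives > 100000 nM, again a limit and not a number. The step that the two limits leave unreadable from compound 1 to compound 2 is therefore unreadable. Within the data shown here, compound 2 thus stands at the limit, where the only other value shown also sits (the limit of > 100000 nM in this assay, at which 2 of the 2 values shown sit).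

Compound 3, `CC#CCn1c(N2CCC[C@@H](N)C2)nc2c1c(=O)n(Cc1ccc(F)cc1C(=O)O)c(=O)n2C`, is not yet measured. It differs from compound 2 by 2-carboxy-4-fluorophenyl in place of 2-carboxy-6-chlorophenyl on a saturated chain carbon bound to an aromatic nitrogen. No readable measured step bears on this change; both measured compounds sit at the limit, so nothing indicates a direction or size. The expected step that the limit leaves unreadable from compound 2 to compound 3 is that compound 3 remains at or near the limit. The estimate for compound 3 in this assay is 150000 nM, with a range from 30000 nM to 1000000 nM, and most probably only a limit will be reported.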

Compound 3, half-maximal inhibitory concentration: > 100000 nM
Compound 3: a limit, no number; the forecaster's own chance of this, stated with the estimate: 80%; the middle value does not contradict the limit.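

In this assay compound 3 gives > 100000 nM, a limit and not a number. No step among compound 1, compound 2 and compound 3 can be read: the limit of > 100000 nM in this assay, at which 3 of the 3 values shown sit.

Left open is whether these three aryl substitution patterns differ at all in inhibition, and by how much.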